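One Fluoro Fewer on the Strongest Leukotriene Antagonist

The source may hold more compounds than are shown below. What is called first, only, known or untested is meant among the compounds shown, and "the series" means these compounds.

Of the compounds shown here, three have been measured in a functional assay on HEK293 cells for antagonist activity at cysteinyl leukotriene receptor 2 (Homo sapiens), read by fluorescence and calcium flux, with stated times of 30 min and 1 h; a higher number here means a weaker inhibitor, a lower number a stronger inhibitor. Compound 1, `Cc1c(CCCC(=O)O)c2cccc(/C=C/c3ccc(OCCCCc4c(F)cc(F)c(F)c4F)cc3)c2n1CC(=O)O`, gives 2.2 nM and stands lowest of the three numbers. Compound 2, `O=C(O)CCCn1cc(CC(=O)O)c2c(/C=C/c3ccc(OCCCCOc4ccccc4)cc3)cccc21`, gives 27 nM, and compound 3, `Cc1c(Cl)cccc1CCCCOc1ccc(C#Cc2cccc3c(CC(=O)O)c(C)n(CCCC(=O)O)c23)cc1`, gives 55 nM; both lie beyond the scatter from compound 1, so compound 1 is the strongest inhibitor of the three. Compound 4, `Cc1c(CCCC(=O)O)c2cccc(/C=C/c3ccc(OCCCCc4c(F)ccc(F)c4F)cc3)c2n1CC(=O)O`, has not yet been measured. It differs from compound 1 in one place: hydrogen in place of fluoro on an aromatic carbon. Put another way, the 2,3,4,6-tetrafluorobenzyl group becomes a 2,3,6-trifluorobenzyl group. For the measured compounds named here, no pair of measured compounds here differs in a single place, so the size of such a step has not been observed directly; compounds 2 and 3 differ from compound 1 in several places at once. The loss of a single fluoro is a small change, and compound 4 is expected to stay close to compound 1, with an expected step of a 1.6-fold higher number from compound 1 to compound 4 (0.20 log units; within the scatter), a mild weakening within or just past the scatter. Compound 4 is therefore estimated at 3.5 nM, within a range of 1.5 nM to 9 nM.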

Compound 4, half-maximal inhibitory concentration: 1 nM
Estimate against measurement, compound 4: 3.5-fold (0.54 log units) above; the measured number lies below the stated range.
By their numbers in this assay, from the lowest: compound 4; then compound 1; then compound 2; then compound 3.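

Taking away the fluoro that stands para to a large group, which turns the 2,3,4,6-tetrafluorobenzyl group into a 2,3,6-trifluorobenzyl group, gives in this assay a 2.2-fold lower number from compound 1 to compound 4 (0.34 log units; beyond the scatter) and offers the first direct view of a single change on this series. This fluoro is therefore not needed for the inhibition seen with compound 1, and plain hydrogen on this aromatic carbon gives a modest gain rather than a loss. Nothing available accounts for that gain.

From the compounds shown here alone, whether a chlorine atom, a methoxy group or a trifluoromethyl group on this same carbon would do better or worse than hydrogen remains open. So does the outcome of replacing any of the three remaining fluoro groups of compound 4 with hydrogen.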